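Pyrazine for pyridine on a solubility series

The source may report more compounds than this note shows. Statements on the series, on what has been measured and on what is new or still open speak of the compounds shown alone.

Three compounds share one core and differ in the aryl group on the aminomethyl chain and in the substituents on the fused ring. Compound 1 `Cc1cc(NCc2ccccn2)n2nc(C)c(-c3ccc(F)cc3)c2n1` was examined in a physicochemical assay for solubility, read by HPLC, using the shake flask method, measured as kinetic solubility, with a stated time of 2 h, at pH 7.4; a lower number here means a less soluble compound, a higher number a more soluble compound. For compound 1 the assay returned only a limit, < 5000 nM, and it is recorded as such (the limit of < 5000 nM in this assay, at which 1 of the 3 values shown sits). Compound 2 `Cc1cc(NCc2ccccn2)n2ncc(Br)c2n1` gives 89300 nM in this assay. Compound 3 `Cc1cc(NCc2cccnc2)n2nc(C)c(-c3ccccc3)c2n1` gives 110000 nM in this assay; its number and that of compound 2 sit within the scatter of each other, so no order between them can be read from these two values. Compound 1 contributes only a limit rather than a number.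

Compound 4 `Cc1cc(NCc2cnccn2)n2nc(C)c(-c3ccccc3)c2n1` has not yet been measured. It differs from compound 3 in a single place: pyrazin-2-yl in place of pyridin-3-yl on a saturated chain carbon bound to a nitrogen on an aromatic ring. For the measured compounds named here, no measured pair in this set shows this change, so its effect in this assay is unknown here. The step expected from compound 3 to compound 4, a 1.1-fold lower number from compound 3 to compound 4 (0.04 log units; within the scatter), is estimated to stay within the scatter, in no firm direction. Compound 4 is therefore expected near 100000 nM in this assay, with a range from 40000 nM to 250000 nM.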

Compound 4, solubility: 7100 nM
Beside the measured number, compound 4's estimate is 14-fold (1.15 log units) above it; the whole stated range lies above it.
By their numbers in this assay, from the lowest: compound 4; then compounds 2 and 3 (each within the scatter of the next). At a limit, below all of these: compound 1.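

In this assay, for the compounds shown here, pyrazin-2-yl in place of pyridin-3-yl on a saturated chain carbon bound to a nitrogen on an aromatic ring gives a 15-fold lower number from compound 3 to compound 4 (1.19 log units; beyond the scatter), the first step in this set between compounds that differ in one place. The reading at this position therefore depends on which ring sits there, even though both rings have the same number of heavy atoms, neither has a hydrogen-bond donor or a net charge, and they differ in their counts of hetero atoms and hydrogen-bond acceptors. Nothing measured in this set accounts for the size of this step.

The compounds shown leave open whether a step of this size belongs to pyrazin-2-yl in general or only to this pairing with the rest of compound 3, since the same change is not seen on a second pair with different substituents on the shared core. They also leave open how another ring with two nitrogens, such as pyrimidin-5-yl, would read at the same place, and so whether the identity of the ring or the placing of its nitrogens carries the step.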